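Ether replacement for the amino ester on the shared core

This account rests on a few compounds, and the source may have more. Where it says the series, first, only, none or still open, it means among the compounds named here.

Compound 1 `CCOC(=O)c1c(F)c(N)c2c(=O)cc(-c3ccc(N)c(F)c3)oc2c1F` carries the ethoxycarbonyl group on the shared core. In a functional assay on HeLa cells (Homo sapiens) for cytotoxicity, read by neutral red uptake, with a stated time of 3 days (on this read-out lower numbers stand for stronger inhibition and higher numbers for weaker inhibition), compound 1 gives > 100000 nM, which is a limit of the assay and not a number (the limit of > 100000 nM in this assay, at which 1 of the 3 values shown sits). Compound 2 `CCCCCC(=O)OCc1c(F)c(N)c2c(=O)cc(-c3ccc(N)c(F)c3)oc2c1F` gives 34000 nM in this assay. Compound 3 `CN(C)CCCC(=O)OCc1c(F)c(N)c2c(=O)cc(-c3ccc(N)c(F)c3)oc2c1F` gives 4500 nM, the lowest of the two numbers. The measured steps are an at least 2.9-fold lower number from compound 1 to compound 2 (0.46 log units; beyond the scatter), an at least 22-fold lower number from compound 1 to compound 3 (1.34 log units; beyond the scatter) and a 7.6-fold lower number from compound 2 to compound 3 (0.88 log units; beyond the scatter).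

Compound 4 `CCCCCCOCc1c(F)c(N)c2c(=O)cc(-c3ccc(N)c(F)c3)oc2c1F` differs from compound 3 by hexyl in place of (3-(dimethylamino)propyl)carbonyl on an oxygen on a saturated carbon. The step from compound 2 to compound 3 bears on this change: compound 2 carries a plain chain without the dimethylamino and sits at the higher number, and compound 4 likewise has no dimethylamino on its chain. Among the measured compounds shown here, the loss of the carbonyl is covered by no measured step. A step back towards the number of compound 2 is therefore expected, namely a 6.7-fold higher number from compound 3 to compound 4 (0.82 log units; beyond the scatter). For compound 4 in this assay the estimate is 30000 nM, within a range of 8000 nM to 100000 nM.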

Compound 4, half-maximal inhibitory concentration: > 100000 nM
Compound 4 ended at the assay's limit; the forecaster's own chance of this, stated with the estimate: 20%; middle value at least 3.3-fold (0.52 log units) from the limit.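

In this assay compound 4 sits at a limit of the assay and not at a number, as compound 1 does: the limit of > 100000 nM in this assay, at which 2 of the 4 values shown sit.

Hexyl in place of (3-(dimethylamino)propyl)carbonyl on this oxygen gives an at least 22-fold higher number from compound 3 to compound 4 (1.34 log units; beyond the scatter), and hexyl in place of pentylcarbonyl gives an at least 2.9-fold higher number from compound 2 to compound 4 (0.46 log units; beyond the scatter). Among the compounds shown here, the second step has no dimethylamino on either side, so the change from ester to ether moves the number upward on its own, which the earlier compounds did not show, while the step between compound 1 and compound 4 cannot be read.

Going by these compounds, whether a dimethylamino group at the end of the ether chain would bring the number back down stays open. So does the outcome for an amide in place of the ester at this position.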